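Thiazole acetic acid series: replacing the amino group

The compounds below may be only part of what the source reports. "The series", "measured", "known", "first", "only" and "open" are said of these compounds alone.

Compounds measured so far:
compound 1 `Nc1nc(-c2ccc(Cl)cc2)c(CC(=O)O)s1`: > 100000 nM
compound 2 `O=C(O)Cc1sc(NC(=O)c2ccccc2)nc1-c1ccc(Cl)cc1`: 520 nM

In an in vitro assay on HEK385-7 cells for displacement of a labelled ligand from prostaglandin D2 receptor 2 (Homo sapiens) (on this read-out higher numbers stand for weaker inhibition and lower numbers for stronger inhibition), compound 1 gives > 100000 nM, which is a limit of the assay and not a number; where compound 1 stands is therefore known only as a bound. For the measured compounds named here, compound 2 carries a benzoyl in place of hydrogen on a nitrogen on an aromatic ring and gives 520 nM in this assay, so the step of an at least 190-fold lower number from compound 1 to compound 2 (2.28 log units; beyond the scatter) is the single comparison available, and its lower end rests on (the limit of > 100000 nM in this assay, at which 1 of the 2 values shown sits).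

The unmeasured compound 3 `O=C(O)Cc1sc(CSc2ccccc2)nc1-c1ccc(Cl)cc1` departs from compound 1 by the change ((phenylsulfanyl)methyl in place of amino on an aromatic carbon). Like compound 2, it places a six-membered aromatic ring of carbon only onto the shared core, here on the aromatic carbon that bore the amino group, and the hydrogen-bond donor is lost. Going by the values given here, the one measured step bearing on this direction, an at least 190-fold lower number from compound 1 to compound 2 (2.28 log units; beyond the scatter), is large and beyond the scatter, so a large fall in the number is expected in this assay for compound 3 as well. The step expected from compound 1 to compound 3 is an at least 83-fold lower number from compound 1 to compound 3 (1.92 log units; beyond the scatter). Compound 3 is therefore estimated at 1200 nM in this assay, with a range from 150 nM to 9000 nM.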

Compound 3, half-maximal inhibitory concentration: 250 nM
The estimate for compound 3 lay 4.8-fold (0.68 log units) above the measured number; measured number inside the range.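

In this assay, (phenylsulfanyl)methyl in place of the amino group gives an at least 400-fold lower number from compound 1 to compound 3 (2.60 log units; beyond the scatter), so at this aromatic carbon a large fall in the number does not depend on the nitrogen and carbonyl that link the ring in compound 2. Compound 1 gives > 100000 nM, which is a limit of the assay and not a number, so this step has only a lower end: the limit of > 100000 nM in this assay, at which 1 of the 3 values shown sits. With compound 2 at 520 nM and compound 3 at 250 nM, the amide hydrogen of compound 2 is not required for a value of this order, as the entering group of compound 3 counts 0 hydrogen-bond donors.

The compounds shown do not separate the contribution of the sulfur from that of the six-membered aromatic ring, and an ether oxygen in place of the sulfur, or a longer chain to the ring, would address this. Also open, from the compounds shown here alone, is how far a fluorine or a methoxy group on that ring would move the number, as would an amine or a second carboxylic acid there.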